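A few compounds are considered here, and "the series" means these few. Any claim that something is new, unique, unknown or untested is made for them only; others in the source may bear on it.

In a functional assay on NCI-H460 cells (Homo sapiens) for antiproliferative activity, with a stated time of 72 h (on this read-out higher numbers stand for weaker inhibition and lower numbers for stronger inhibition), compound 1 `C=C1C=CC(=O)[C@@H]2[C@H](Cc3ccc(OCOC)cc3)CC[C@H]12` gives 226 nM and compound 2 `C=C1C=CC(=O)[C@@H]2[C@H](Cc3ccc(OCOC)c(F)c3)CC[C@H]12` gives 106 nM, the lowest number among those shown. Compound 3 `C=C1C=CC(=O)[C@@H]2[C@H](Cc3cc(OC)c(OC)c(OC)c3)CC[C@H]12` reads > 1000 nM, which is a limit and not a number. All three share one core and differ in the groups on an aromatic ring. Going by the values given here, the only measured step, fluoro in place of hydrogen on an aromatic carbon, is a 2.1-fold lower number from compound 1 to compound 2 (0.33 log units; beyond the scatter), which is modest but beyond the scatter.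

Compound 4 `C=C1C=CC(=O)[C@@H]2[C@H](Cc3ccc(F)c(F)c3)CC[C@H]12` has not yet been measured. It differs from compound 2 by one change, fluoro in place of methoxymethoxy on an aromatic carbon, ortho to a fluoro group and para to a large group: fluoro in place of methoxymethoxy on an aromatic carbon. Among the compounds with values here, no measured step makes this exchange, so the fluoro step is only a loose guide to size. Compound 2, at 106 nM, still carries methoxymethoxy, and so does compound 1, which leaves its removal untested. A modest move towards a higher number, meaning weaker inhibition, is therefore expected in this assay, although a change within the scatter remains possible. The expected change is a 2.1-fold higher number from compound 2 to compound 4 (0.32 log units; beyond the scatter). For compound 4 the estimate is 220 nM, with an expected range from 60 nM to 800 nM.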

Compound 4, half-maximal inhibitory concentration: 511 nM
Beside the measured number, compound 4's estimate is 2.3-fold (0.37 log units) below it, within the range that was stated.
By their numbers in this assay, from the lowest: compound 2; then compound 1; then compound 4. At a limit, above all of these: compound 3.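

In this assay, going by these compounds alone, the exchange of methoxymethoxy for fluoro gives a 4.8-fold higher number from compound 2 to compound 4 (0.68 log units; beyond the scatter), the first measured change at this place, since compounds 1 and 2 both carry methoxymethoxy there. The step shows that, with a fluoro group kept ortho to this position, replacing the methoxymethoxy group with a single fluoro atom weakens inhibition. Compound 4 still gives a measured number rather than a limit, so methoxymethoxy is not required for a readable effect on these cells in this set.

This single exchange removes a four-atom group and adds a fluoro atom at once, so it cannot separate the loss of one from the gain of the other, and a hydroxy group, an amine or an ethoxy chain at the same place would help to tell them apart. Compound 3 offers no size of change to set beside this step, as its value is a limit and not a number: the limit of > 1000 nM in this assay, at which 1 of the 4 values shown sits.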